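Swapping the aryloxy group for chlorine on the core

This account rests on a few compounds, and the source may have more. Where it says the series, first, only, none or still open, it means among the compounds named here.

Compound 1 `Cc1nnsc1CO/N=C/c1c(C)nn(C)c1Oc1cccc(F)c1` and compound 2 `Cc1ccc(Oc2c(/C=N/OCc3snnc3C)c(C)nn2C)cc1` share one core. In a functional assay on Huh-7 cells (Homo sapiens) for inhibition, read by MTT assay, with a stated time of 48 h (a higher number here means a weaker inhibitor, a lower number a stronger inhibitor), compound 1 gives > 50000 nM, which is a limit of the assay and not a number. In this assay compound 2 gives > 50000 nM, likewise a limit. The step that the two limits leave unreadable from compound 1 to compound 2 is therefore unreadable, since (the limit of > 50000 nM in this assay, at which 2 of the 2 values shown sit). Compound 3 `Cc1nnsc1CO/N=C/c1c(C)nn(C)c1Cl` differs from compound 2 by chloro in place of 4-methylphenoxy on an aromatic carbon. Among the measured compounds shown here, no measured step touches this change, so the measured compounds point to neither a direction nor a size. Compound 3 is therefore expected to give 50000 nM, between 15000 nM and 200000 nM. The expected step of a number no higher from compound 2 to compound 3 (the limit leaves the size open) is none beyond the scatter.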

Compound 3, half-maximal inhibitory concentration: > 50000 nM
Compound 3: no number, only a limit; the forecaster's own chance of this, stated with the estimate: 80%; the middle value sits exactly at the limit.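

Compound 3 also gives only a limit in this assay, so none of the steps among compound 1, compound 2 and compound 3 can be read: the limit of > 50000 nM in this assay, at which 3 of the 3 values shown sit.

The compounds shown leave open how chloro, 3-fluorophenoxy and 4-methylphenoxy compare on the shared core, and which change, if any, would give a readable number.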